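The source may report more compounds than this note shows. Statements on the series, on what has been measured and on what is new or still open speak of the compounds shown alone.

Measured compounds in a functional assay on CHO cells for antagonist activity at adenosine receptor A2b (Homo sapiens), read by cAMP accumulation, with a stated time of 10 min; on this read-out higher numbers stand for weaker inhibition and lower numbers for stronger inhibition:

Compound 1 `Nc1nc(-c2ccc(CO)cc2)nc2sc(-c3ccccc3)nc12` gives > 30000 nM, which is a limit of the assay.
Compound 2 `COc1cccc(-c2nc(N)c3nc(-c4ccccc4)sc3n2)c1` gives > 30000 nM, also a limit.
Compound 3 `Nc1nc(-c2ccco2)nc2sc(-c3ccccc3)nc12` gives > 30000 nM, again a limit.

Compound 2 stands at the same limit as the other two members of the series; (the limit of > 30000 nM in this assay, at which 3 of the 3 values shown sit). The three measured steps are unreadable: a step that the two limits leave unreadable from compound 1 to compound 2, a step that the two limits leave unreadable from compound 1 to compound 3 and a step that the two limits leave unreadable from compound 2 to compound 3, none of them with a readable size, all of them varying the group on the shared core at a position other than the one now in question.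

Compound 4 `COc1cccc(-c2nc(N)c3nc(-c4ccco4)sc3n2)c1` differs from compound 2 as follows: furan-2-yl in place of phenyl on an aromatic carbon. Going by the values given here, no measured step touches this position on the five-membered ring, so the measured steps bear on the new change only in that every variation so far has left the series at the limit. The step from compound 2 to compound 4 is therefore expected to be a number no higher from compound 2 to compound 4 (the limit leaves the size open) in this assay, with no readable direction. For compound 4 the estimate in this assay is 30000 nM, within 10000 nM to 100000 nM, most probably reported as a limit again.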

Compound 4, half-maximal inhibitory concentration: > 30000 nM
Compound 4: only a limit was reported; the forecaster's own chance of this, stated with the estimate: 75%; the middle value lies on the limit itself.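

Compound 4 gives > 30000 nM, a limit and not a number, so the change from compound 2 to compound 4 yields no readable step. The compounds shown leave open whether any change on the shared core gives a measurable inhibition, as the series stays at: the limit of > 30000 nM in this assay, at which 4 of the 4 values shown sit.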